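The source may report more compounds than this note shows. Statements on the series, on what has been measured and on what is new or still open speak of the compounds shown alone.

Measured in a functional assay on HepG2 cells (Homo sapiens) for cytotoxicity, read by MTT assay, with a stated time of 72 h; on this read-out lower numbers stand for stronger inhibition and higher numbers for weaker inhibition:
- compound 1 `O=C(N/N=C/c1cccc(Br)c1)Nc1cc2c(Nc3ccc(F)c(Cl)c3)ncnc2cc1O[C@H]1CCOC1`: 32300 nM
- compound 2 `CC(C)(C)c1cc(/C=N/NC(=O)Nc2cc3c(Nc4ccc(F)c(Cl)c4)ncnc3cc2O[C@H]2CCOC2)cc(C(C)(C)C)c1O`: 12500 nM
- compound 3 `COc1cc2ncnc(Nc3ccc(F)c(Cl)c3)c2cc1NC(=O)N/N=C/c1cccc(Br)c1`: "not active" (no number reported)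

Compound 3 has no single number in this assay. It is reported only as "not active" (no number reported), so it cannot be placed exactly against the two measured compounds. Compound 4 `COc1cc2ncnc(Nc3ccc(F)c(Cl)c3)c2cc1NC(=O)N/N=C/c1ccc(OC)c(OC)c1OC` has not yet been measured. The change is 2,3,4-trimethoxyphenyl in place of 3-bromophenyl on a carbon with a double bond to nitrogen, with 2,3,4-trimethoxyphenyl in place of 3-bromophenyl on a carbon with a double bond to nitrogen. Among the measured compounds shown here, no measured step gives this change a size. Only a small move towards a weak but measurable inhibition is expected in this assay, and another report without a number remains quite possible. For compound 4 the estimated value is 25000 nM, with an expected range of 8000 nM to 80000 nM.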

Compound 4, half-maximal inhibitory concentration: 31200 nM
Beside the measured number, compound 4's estimate is 1.2-fold (0.10 log units) below it, within the range that was stated.
By their numbers in this assay, from the lowest: compound 2; then compounds 4 and 1 (each within the scatter of the next).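

In this assay compound 3 has no number while compound 4 gives 31200 nM and no step can be read between them. The compounds shown leave open how much 2,3,4-trimethoxyphenyl in place of 3-bromophenyl changes the value. No evidence bears on this result.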